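Swapping Fluoro for Bromo on an Inactive Thiourea Scaffold

This account rests on a few compounds, and the source may have more. Where it says the series, first, only, none or still open, it means among the compounds named here.

Two compounds share one core and differ only in the groups attached to it. Compound 1 `NC(=O)c1c(NC(=O)c2ccccc2I)sc2c1CCN(C(=S)Nc1ccccc1Br)C2` carries an iodobenzamide and a bromophenyl thiourea, while compound 2 `NC(=O)c1c(NC(=O)c2ccccc2C(F)(F)F)sc2c1CCN(C(=S)Nc1ccccc1F)C2` carries a trifluoromethyl benzamide and a fluorophenyl thiourea. In a functional assay on HeLa cells (Homo sapiens) for antiproliferative activity, with a stated time of 24 h (on this read-out lower numbers stand for stronger inhibition and higher numbers for weaker inhibition), compound 1 reaches only the assay limit, > 50000 nM. In this assay compound 2 likewise reaches only a limit, > 50000 nM. Compound 2 therefore stands where every value here stands, at the edge of what the assay can report, (the limit of > 50000 nM in this assay, at which 2 of the 2 values shown sit). Compound 3 `NC(=O)c1c(NC(=O)c2ccccc2C(F)(F)F)sc2c1CCN(C(=S)Nc1ccccc1Br)C2` keeps the trifluoromethyl benzamide of compound 2 and changes the thiourea side: bromo in place of fluoro on an aromatic carbon. Going by the values given here, no step between measured compounds is available to judge this change. With both neighbours at the limit, no shift beyond the scatter is expected, and the estimated step is a step that the limit leaves unreadable from compound 2 to compound 3. Compound 3 is expected to give 80000 nM, within 30000 nM to 300000 nM, most likely again reported only as a limit.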

Compound 3, half-maximal inhibitory concentration: > 50000 nM
Compound 3: only a limit was reported; the forecaster's own chance of this, stated with the estimate: 85%; the middle value does not contradict the limit.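

Compound 3 gives only a limit, > 50000 nM, in this assay. The steps to compound 3 from compound 2 and from compound 1 therefore cannot be read: the limit of > 50000 nM in this assay, at which 3 of the 3 values shown sit. On these data alone, whether swapping fluoro for bromo, or iodo for trifluoromethyl, alters antiproliferative activity at all remains open.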